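Nitro for chloro on the phenoxy ring of compound 1

This account rests on a few compounds, and the source may have more. Where it says the series, first, only, none or still open, it means among the compounds named here.

Compound 1 `O=C(CSc1nc2ccccc2s1)N/N=C/c1ccc(Oc2ccc(Cl)cc2)cc1` is one of three measured members of this series. In a physicochemical assay for lipophilicity, in phosphate buffer, measured as octanol-water partition, with a stated time of 24 h (a higher number here means a more lipophilic compound, a lower number a more polar compound), compound 1 gives 5.6 and stands level with compound 3 `C(=N/Nc1nc2ccccc2s1)\c1ccc(Oc2ccc3ccccc3c2)cc1` at the digits shown, which in this assay gives 5.6; together they are the highest two of the three numbers. The furthest from compound 1 is compound 2 `O=[N+]([O-])c1ccc(Oc2ccc(/C=N/Nc3nc4ccccc4s3)cc2)cc1`, which in this assay gives 5.1, a number beyond the scatter below compound 1. Compound 2 and compound 3 differ from compound 1 in more than one place, so no single step can be read from them; their two values only show a gap of the size printed.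

Compound 4 `O=C(CSc1nc2ccccc2s1)N/N=C/c1ccc(Oc2ccc([N+](=O)[O-])cc2)cc1` is the next member to be measured. It differs from compound 1 by nitro in place of chloro on an aromatic carbon. Among the measured compounds shown here, no step between measured compounds shows this change on its own. For the measured compounds named here, compound 2, the only measured member carrying a nitro group, sits lowest of the three, and the expected step from compound 1 to compound 4 in this assay is a decrease of moderate size, a number 0.90 log units lower from compound 1 to compound 4 (beyond the scatter), beyond the scatter. For compound 4 the estimated value in this assay is 4.7, with a range from 4.2 to 5.2.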

Compound 4, partition coefficient: 5.3
Compound 4: the middle estimate sits 0.60 log units below what was measured; the whole stated range lies below it.
By their numbers in this assay, from the lowest: compounds 2, 4, 1 and 3 (each within the scatter of the next, the first and the last beyond it).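

Among the compounds shown here, the pair gives the first reading of a single change: in this assay, nitro in place of chloro on an aromatic carbon, para to a large group, comes out as a number 0.30 log units lower from compound 1 to compound 4 (within the scatter) and so does not separate the two compounds on this core. The exchange brings in three heavy atoms for one and two hydrogen-bond acceptors where chloro counts none, and with the core of compound 1 held fixed, that difference in counts leaves the read-out within the scatter. No measured property bears on the size of this step, so nothing can be said about its cause.

On these data alone, the steps linking compound 2 or compound 3 to the other compounds cannot be read, so it stays open whether the exchange of chloro for nitro gives a step of like size on the core of compound 2. Also open, as far as these compounds go, is how this assay responds at this position to other groups, such as an amine, a carboxylic acid or a longer alkyl chain.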